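Trimming an Ethyl to a Methyl on the Anilide Ring

The source may report more compounds than this note shows. Statements on the series, on what has been measured and on what is new or still open speak of the compounds shown alone.

Compound 1 `CCc1cccc(NC(=O)CN2CCN(c3ccccn3)CC2)c1`: in an assay on HEK293 cells for displacement of a labelled ligand from D(4) dopamine receptor (Homo sapiens), read by scintillation counting, with a stated time of 60 min (a higher number here means a weaker inhibitor, a lower number a stronger inhibitor), compound 1 gives 67.9 nM.
Compound 2 `CCc1cccc(NC(=O)CN2CCN(c3ccc(Cl)cn3)CC2)c1`: in this assay compound 2 gives 172 nM.
Compound 3 `Cc1cccc(NC(=O)CCN2CCN(c3ncccn3)CC2)c1`: in this assay compound 3 gives 526 nM.

Compound 1 has the lowest number of the three. Compound 2 is nearest, and the step of a 2.5-fold higher number from compound 1 to compound 2 (0.40 log units; beyond the scatter) is modest. Compound 3 is furthest away, yet it differs from compound 1 in several places at once, so its value alone says nothing about any single change.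

Compound 4 `Cc1cccc(NC(=O)CN2CCN(c3ccccn3)CC2)c1` differs from compound 1 by hydrogen in place of methyl on a saturated chain carbon bound to an aromatic carbon. Among the measured compounds shown here, no measured step isolates this change: the only other methyl-bearing compound, compound 3, also carries a different chain and a different ring, so the gap between compound 1 and compound 3 cannot be credited to the methyl. A small step, at most a slight weakening, is therefore expected for compound 4, amounting to a 1.5-fold higher number from compound 1 to compound 4 (0.17 log units; within the scatter). The estimate for compound 4 in this assay is 100 nM, with a range of 40 nM to 250 nM.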

Compound 4, inhibition constant: 212 nM
Compound 4: middle estimate off by 2.1-fold (0.33 log units), on the low side; measured number inside the range.
By their numbers in this assay, from the lowest: compound 1; then compounds 2 and 4 (each within the scatter of the next); then compound 3.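

Among the compounds shown here, removing one carbon from the chain matters here: in this assay, going from 3-ethylphenyl to 3-methylphenyl gives a 3.1-fold higher number from compound 1 to compound 4 (0.49 log units; beyond the scatter) and is the first change at this position that can be read on its own. The step shows that the ethyl gives a lower number than the methyl on an otherwise unchanged core. The data offer no measured explanation for this difference.

Still open, going by these compounds, is whether a longer chain, such as propyl, or a branched one, such as isopropyl, would lower the number further. Also open, on these data alone, is whether the same step would appear on the chloro-bearing compound 2.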